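The compounds below may be only part of what the source reports. "The series", "measured", "known", "first", "only" and "open" are said of these compounds alone.

Series notes. Compound 1 `CC1CCN(C2CCN(S(=O)(=O)c3cn(C)cn3)CC2)CC1` carries the shared core with the sulfonyl sulfur. In an ADME assay on HCT-116 cells (Homo sapiens) for cytotoxicity, read by CellTiter-Glo, with a stated time of 72 h (on this read-out higher numbers stand for weaker inhibition and lower numbers for stronger inhibition), compound 1 gives only a limit, > 10000 nM, so no number is known for it. Compound 2 `CC1CCN(C2CCN(S(=O)(=O)c3ccc(OCc4ccccc4)cc3)CC2)CC1` also gives a limit in this assay, > 5000 nM. Compound 3 `CC1CCN(C2CCN(S(=O)(=O)c3ccccc3-c3ccc(C(F)(F)F)cc3)CC2)CC1` likewise gives a limit, > 5000 nM, in this assay. All three values therefore sit at limits: the limit of > 10000 nM in this assay, at which 1 of the 3 values shown sits, and (the limit of > 5000 nM in this assay, at which 2 of the 3 values shown sit). Compound 4 `CC1CCN(C2CCN(S(=O)(=O)c3ccc(Cl)c(Cl)c3)CC2)CC1` is not yet measured; relative to compound 1 the change is 3,4-dichlorophenyl in place of 1-methyl-1H-imidazol-4-yl on a sulfonyl sulfur, a change on the sulfonyl sulfur. For the measured compounds named here, no step between measured compounds is known, and the three limits leave the direction open. The expected step of an at least 1.2-fold lower number from compound 1 to compound 4 (0.09 log units; that floor lies within the scatter) is none beyond the scatter, with a further limit the likelier outcome. Compound 4 is thus expected at 8000 nM, within 2500 nM to 30000 nM.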

Compound 4, half-maximal inhibitory concentration: > 5000 nM
Compound 4: a limit, no number; the forecaster's own chance of this, stated with the estimate: 70%; the middle value lies beyond the limit too.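

For the compounds shown here, compound 1 and compound 4 both give only limits in this assay, and no step between them can be read. The compounds shown leave open whether any change on the sulfonyl sulfur shifts the read-out at all.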